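The compounds below may be only part of what the source reports. "The series", "measured", "known", "first", "only" and "open" are said of these compounds alone.

Measured in an ADME assay on BJ cells (Homo sapiens) for cytotoxicity, read by luminescence, with a stated time of 72 h; a higher number here means that more compound is needed for the effect, a lower number that less compound is needed:
- Compound 1 `CCOC(=O)c1c(-c2cccc(OCC)c2)[nH]c2cc(OC)ccc2c1=O`: > 21500 nM
- Compound 2 `CCOC(=O)c1c(-c2cccc(S(C)(=O)=O)c2)[nH]c2cc(OC)ccc2c1=O`: > 21500 nM
- Compound 3 `CCOC(=O)c1c(-c2cccc(N(C)C)c2)[nH]c2cc(OC)ccc2c1=O`: > 21500 nM

Each of these entries is a limit of the assay and not a number. Compound 3 therefore has no exact position on the scale, and it shares its place with the other two: the limit of > 21500 nM in this assay, at which 3 of the 3 values shown sit.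

The next compound, compound 4 `CCOC(=O)c1c(-c2cccc(NC(C)=O)c2)[nH]c2cc(OC)ccc2c1=O`, carries acetamido in place of dimethylamino on an aromatic carbon. The new group has a hydrogen-bond donor, which the old group lacks.

The measured steps closest to this change are the two that involve dimethylamino: a step that the two limits leave unreadable from compound 1 to compound 3 and a step that the two limits leave unreadable from compound 2 to compound 3. The remaining one, a step that the two limits leave unreadable from compound 1 to compound 2, also changes the group on that aromatic carbon. None of the three has a readable size, so they give only weak guidance. Even so, ethoxy, methylsulfonyl and dimethylamino all end at the same limit.

No step beyond the usual scatter is expected in this assay, in either direction, because compound 3 stands at > 21500 nM. The estimate, which carries this uncertainty, is a number no higher from compound 3 to compound 4 (the limit leaves the size open). The most likely report is another limit rather than a number. For compound 4 the expected value is 21500 nM, with an estimated range from 12000 nM to 40000 nM.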

Compound 4, half-maximal effective concentration: > 21500 nM
Compound 4: a limit, no number; the forecaster's own chance of this, stated with the estimate: 90%; the middle value sits exactly at the limit.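

Compound 4 also gives a limit of the assay and not a number, so its steps from compound 1, compound 2 and compound 3 cannot be read: the limit of > 21500 nM in this assay, at which 4 of the 4 values shown sit.

The compounds shown leave open whether ethoxy, methylsulfonyl, dimethylamino and acetamido on that aromatic carbon differ at all in this assay.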